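Epimer at the Ring Carbon: Compound 3 to Compound 4

This account rests on a few compounds, and the source may have more. Where it says the series, first, only, none or still open, it means among the compounds named here.

The study measures agonist activity in an assay on HEK293 cells for agonist activity at probable G-protein coupled receptor 34 (Mus musculus), with a stated time of 1 h; on this read-out lower numbers stand for smaller maximal responses and higher numbers for larger maximal responses. Two open-chain analogues set the scale: compound 1 `CCCCCCCC/C=C\CCCCCCCC(=O)OC[C@H](C)OP(=O)(O)OC[C@H](N)C(=O)O` gives 11.2% in this assay, and compound 2 `CCCCCCCC/C=C\CCCCCCCC(=O)OC[C@@H](COCC)OP(=O)(O)OC[C@H](N)C(=O)O` gives 12.3% in this assay. These two values lie within the scatter of one another, so neither can be called the larger response.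

Compound 3 `CCCCCCCCCCCOc1ccccc1CCC(=O)O[C@H]1CCOC[C@H]1OP(=O)(O)OC[C@H](N)C(=O)O` carries a saturated ring in place of the open chain and an aryl-bearing acyl group. In this assay compound 3 is reported as "not active" (no number reported), and no number was recorded for it, so it cannot be placed on the same scale as compound 1 and compound 2; it simply stands at the bottom, without a value.

Compound 4 `CCCCCCCCCCCOc1ccccc1CCC(=O)O[C@@H]1CCOC[C@H]1OP(=O)(O)OC[C@H](N)C(=O)O` is its ring epimer. The change from compound 3 to compound 4 is the two compounds have the same atoms and bonds; at least one stereo element is drawn with a configuration in one of them and without one in the other: 1 of 4 stereo elements differ; a stereocentre at a saturated ring carbon is drawn S in compound 3 and R in compound 4. Among the measured compounds shown here, no measured step of this kind exists among the compounds here, so the size and direction of the change in this assay are unknown; a change beyond the scatter in either direction is possible, as is none at all.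

Compound 4 is expected to give about 15% in this assay, with a likely range from 0% to 50%.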

Compound 4, largest response reached (Emax), in percent of the reference or control that the assay uses: 10.3%
Compound 4: the middle estimate sits 4.7 percentage points above what was measured; low and high end bracket the measured number.
By their numbers in this assay, from the lowest: compounds 4, 1 and 2 (each within the scatter of the next).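

No step can be read between compound 3 and compound 4: compound 3 has no number in this assay, while compound 4 gives 10.3%. The compounds shown leave open how far the configuration at the saturated ring carbon alters the response, and the pair offers only this to go on: the fact that one of compounds 3 and 4 is drawn with a defined configuration and the other without, at the place where they differ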